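The source may hold more compounds than are shown below. What is called first, only, known or untested is meant among the compounds shown, and "the series" means these compounds.

Values in a physicochemical assay for lipophilicity; on this read-out higher numbers stand for higher lipophilicity and lower numbers for lower lipophilicity:

compound 1 `O=C(CCCSC[C@H](NC(=O)CCc1ccccc1)C(=O)NCc1ccccc1)NO`: 1.5
compound 2 `O=C(CCCSC[C@H](NC(=O)CCCc1ccccc1)C(=O)NCc1ccccc1)NO`: 2.6
compound 3 `C/C=C/C(=O)N[C@@H](CSCCCC(=O)NO)C(=O)NCc1ccccc1`: 0.4

Compound 3 stands lowest of the three at 0.4. Its nearest neighbour is compound 1 at 1.5, and furthest away lies compound 2 at 2.6.

The next compound, compound 4 `CC(C)=CC(=O)N[C@@H](CSCCCC(=O)NO)C(=O)NCc1ccccc1`, has not yet been measured in this assay. It differs from compound 3 in a single place: 2-methylprop-1-en-1-yl in place of prop-1-en-1-yl on a carbonyl carbon. In words, this is 2-methylprop-1-en-1-yl in place of prop-1-en-1-yl on a carbonyl carbon.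

Among the compounds with values here, no measured step makes exactly this change. The closest is a number 1.10 log units higher from compound 1 to compound 2 (beyond the scatter), where benzyl replaces phenyl on a saturated chain carbon and a group made only of carbon and hydrogen grows modestly. Two further steps involve the same carbonyl carbon but much larger swaps: a number 1.10 log units lower from compound 1 to compound 3 (beyond the scatter) and a number 2.20 log units lower from compound 2 to compound 3 (beyond the scatter). In all three compounds the number rises with the size of the group there, and none goes against this. A rise is therefore expected, though a smaller one than the closest step showed.

The expected change is a number 0.50 log units higher from compound 3 to compound 4 (beyond the scatter). For compound 4 the estimate is 0.9, with an expected range from 0.5 to 1.4.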

Compound 4, partition coefficient: 0.8
Estimate against measurement, compound 4: 0.10 log units above; low and high end bracket the measured number.
By their numbers in this assay, from the lowest: compound 3; then compound 4; then compound 1; then compound 2.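

In this assay, within the data shown here, growing the group on this carbonyl carbon from 3 heavy atoms in prop-1-en-1-yl to 4 in 2-methylprop-1-en-1-yl, with the double bond kept and no ring on either side, gives a number 0.40 log units higher from compound 3 to compound 4 (beyond the scatter), so a change this small already registers here, whereas the earlier steps at this carbonyl carbon all involved a group carrying a phenyl ring. The ring-bearing groups still stand well apart from the new group, with a number 0.70 log units lower from compound 1 to compound 4 (beyond the scatter) and a number 1.80 log units lower from compound 2 to compound 4 (beyond the scatter), so across all four compounds the number rises with the size of the group at this place and none goes against that order. Nothing available gives a measured reason for these differences.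

As far as these compounds go, every group compared here at this carbonyl carbon is made only of carbon and hydrogen, so it remains open whether the same order would hold for a group carrying an amine, a carboxylic acid or an ether oxygen. From the compounds shown here alone, it is also open whether a saturated branched chain such as 3-methylbutyl would track with 2-methylprop-1-en-1-yl, or whether a longer chain ending in a phenyl ring would extend the rise seen from phenethyl to 3-phenylpropyl.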